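Solubility notes: tert-butyl ketone replaces 4-methoxyphenyl ketone

The source may hold more compounds than are shown below. What is called first, only, known or untested is meant among the compounds shown, and "the series" means these compounds.

Compound 3 `COc1ccc(C(=O)C2=C(O)C(=O)N(c3ccc(-c4ccon4)cc3)C2c2ccccc2OC)cc1` gives 34700 nM in a physicochemical assay for solubility, in phosphate buffer, at pH 6.8 (on this read-out lower numbers stand for lower solubility and higher numbers for higher solubility), the highest of the three numbers in hand. Compound 1 `CNC(=O)c1ccc(C(=O)C2=C(O)C(=O)N(c3ccc(-c4ccon4)cc3)C2C2CCCCC2)cc1` gives 27000 nM in this assay, within the scatter of compound 3. Compound 2 `CCC(CC)C1C(C(=O)c2ccc(OC)cc2)=C(O)C(=O)N1c1ccc(-c2ccon2)cc1` gives 2200 nM, well below both. Compound 4 `COc1ccccc1C1C(C(=O)C(C)(C)C)=C(O)C(=O)N1c1ccc(-c2ccon2)cc1` carries tert-butyl in place of 4-methoxyphenyl on a carbonyl carbon. Among the measured compounds shown here, the only measured step with a bearing is a 16-fold higher number from compound 2 to compound 3 (1.20 log units; beyond the scatter), where a methoxyphenyl group entered for an alkyl group at another place and the number rose sharply. Going by these compounds, the present change runs the other way, alkyl for methoxyphenyl, so a drop beyond the scatter is expected, though its size at the carbonyl carbon is untested. Compound 4 is therefore expected at 7000 nM, range 2000 nM to 25000 nM. The expected step is a 5.0-fold lower number from compound 3 to compound 4 (0.70 log units; beyond the scatter).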

Compound 4, solubility: 29600 nM
Compound 4: middle estimate off by 4.2-fold (0.63 log units), on the low side; measured number outside the range, above it.
By their numbers in this assay, from the lowest: compound 2; then compounds 1, 4 and 3 (each within the scatter of the next).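

In this assay the exchange on the carbonyl carbon gives a 1.2-fold lower number from compound 3 to compound 4 (0.07 log units; within the scatter) so the aromatic ring of 4-methoxyphenyl can leave with no readable change, at least with 2-methoxyphenyl on the saturated ring carbon. Among the compounds shown here, the large step at that other place, a 16-fold higher number from compound 2 to compound 3 (1.20 log units; beyond the scatter) has no counterpart at this one. Nothing available accounts for the difference between the two places.

Open, going by these compounds, is whether tert-butyl behaves the same with pentan-3-yl on the saturated ring carbon. Also open, on these data alone, is what an amine or a carboxylic acid would do on the carbonyl carbon.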